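This account rests on a few compounds, and the source may have more. Where it says the series, first, only, none or still open, it means among the compounds named here.

The series shares one core, first seen in compound 1 `COc1ccc(S(=O)(=O)N2CCc3cccc(NC(=O)c4ccncc4)c32)cc1`, where the carbonyl carbon carries pyridin-4-yl; in a functional assay on MKN-45 cells (Homo sapiens) for cytotoxicity (on this read-out higher numbers stand for weaker inhibition and lower numbers for stronger inhibition), compound 1 gives 8.8 nM. Compound 2 `COc1ccc(S(=O)(=O)N2CCc3cccc(NC(C)=O)c32)cc1` carries methyl on that carbonyl carbon, and in this assay compound 2 gives 61 nM, a step of a 6.9-fold higher number from compound 1 to compound 2 (0.84 log units; beyond the scatter). Compound 3 `COc1ccc(S(=O)(=O)N2CCc3cccc(NC(=O)N(C)c4ccccc4)c32)cc1` carries methyl(phenyl)amino on the carbonyl carbon. In this assay compound 3 gives only > 10000 nM, a limit of the assay rather than a number, sitting at the limit of > 10000 nM in this assay, at which 1 of the 3 values shown sits. The steps into compound 3 were an at least 1100-fold higher number from compound 1 to compound 3 (3.05 log units; beyond the scatter) and an at least 160-fold higher number from compound 2 to compound 3 (2.21 log units; beyond the scatter).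

Compound 4 `COC(=O)c1ccc(C(=O)Nc2cccc3c2N(S(=O)(=O)c2ccc(OC)cc2)CC3)cc1` differs from compound 3 by 4-(methoxycarbonyl)phenyl in place of methyl(phenyl)amino on a carbonyl carbon. This undoes the methyl(phenyl)amino substitution and restores an aryl group on the carbonyl carbon, as in compound 1 with its 8.8 nM. The measured steps that bear on it are the two large ones into compound 3, so a large step back in the stronger direction is expected in this assay, the expected step being an at least 500-fold lower number from compound 3 to compound 4 (2.69 log units; beyond the scatter). Compound 4 is therefore expected to give about 20 nM, within 5 nM to 120 nM.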

Compound 4, half-maximal inhibitory concentration: 312 nM
Beside the measured number, compound 4's estimate is 16-fold (1.19 log units) below it; measured number above the stated range.
By their numbers in this assay, from the lowest: compound 1; then compound 2; then compound 4. At a limit, above all of these: compound 3.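

The first new step, an at least 32-fold lower number from compound 3 to compound 4 (1.50 log units; beyond the scatter), is only a bound, as its starting point is a limit of the assay: the limit of > 10000 nM in this assay, at which 1 of the 4 values shown sits.

An aryl group on the carbonyl carbon does not by itself give the level of compound 1, as 4-(methoxycarbonyl)phenyl in place of pyridin-4-yl gives a 35-fold higher number from compound 1 to compound 4 (1.55 log units; beyond the scatter). Nor do the aryl groups rank together above methyl, since a 5.1-fold higher number from compound 2 to compound 4 (0.71 log units; beyond the scatter), leaving methyl between pyridin-4-yl and 4-(methoxycarbonyl)phenyl in this assay.

The compounds shown leave open whether the loss goes with the carbon-only aromatic ring or with the methoxycarbonyl group, and unsubstituted phenyl on the carbonyl carbon would separate the two. Also open, from the compounds shown here alone, is how a carboxylic acid or a primary amide in place of the methyl ester would read.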